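The compounds below may be only part of what the source reports. "The series", "measured", "known", "first", "only" and "open" are said of these compounds alone.

In an assay on CHO cells for displacement of a labelled ligand from melanin-concentrating hormone receptor 1 (Rattus norvegicus), read by scintillation counting, with a stated time of 1 h (on this read-out higher numbers stand for weaker inhibition and lower numbers for stronger inhibition), compound 2 `Cn1c(C2CC2)nc2ccc(-n3ccc(OCc4csc(Cl)c4)cc3=O)cc21` gives 9.3 nM, and compound 1 `Cn1c(C2CC2)nc2ccc(-n3ccc(OCc4ccc(Cl)s4)cc3=O)cc21` gives 11 nM; the two sit within the scatter of each other, as a 1.2-fold lower number from compound 1 to compound 2 (0.07 log units; within the scatter) shows. Compound 3 `Cn1c(C2CC2)nc2ccc(-n3ccc(OCc4cc(C(F)(F)F)cs4)cc3=O)cc21` carries 4-(trifluoromethyl)thiophen-2-yl in place of 5-chlorothiophen-3-yl on a saturated chain carbon bound to an oxygen on an aromatic ring. Within the data shown here, the only measured step, the shift of the attachment point, left the number essentially unchanged, and no measured pair speaks to trifluoromethyl in place of chlorine on the thiophene. Compound 3 is therefore expected to show at most a small step in this assay, a 1.6-fold higher number from compound 2 to compound 3 (0.21 log units; within the scatter), in no firm direction. The estimate for compound 3 is 15 nM, ranging from 5 nM to 45 nM.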

Compound 3, half-maximal inhibitory concentration: 17 nM
Estimate against measurement, compound 3: 1.1-fold (0.05 log units) below, within the range that was stated.
By their numbers in this assay, from the lowest: compounds 2, 1 and 3 (each within the scatter of the next).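

In this assay, the step to 4-(trifluoromethyl)thiophen-2-yl, with 9 heavy atoms against 6 in 5-chlorothiophen-3-yl, reads as a 1.8-fold higher number from compound 2 to compound 3 (0.26 log units; within the scatter), and the step from 5-chlorothiophen-2-yl reads as a 1.5-fold higher number from compound 1 to compound 3 (0.19 log units; within the scatter). This shows that a thiophene bearing trifluoromethyl instead of chlorine can occupy this place, on a saturated chain carbon bound to an oxygen on an aromatic ring, without a step beyond the scatter, which the two chlorine compounds alone could not show. No evidence is available that bears on this result. The compounds shown leave open whether the thiophene itself is needed, and how a phenyl ring, an amine or a carboxylic acid would read at this place.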